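The source may report more compounds than this note shows. Statements on the series, on what has been measured and on what is new or still open speak of the compounds shown alone.

Compound 1 `CS(=O)(=O)Oc1ccc(-c2cncn2C2CCN(C(=O)c3ccc(Cl)c(C(F)(F)F)c3)CC2)cc1` gives 1570 nM in an assay on HEK293 cells for antagonist activity at P2X purinoceptor 7 (Homo sapiens), read by fluorescence, with a stated time of 2 h; on this read-out higher numbers stand for weaker inhibition and lower numbers for stronger inhibition.
Compound 2 `O=C(c1ccc(Cl)c(C(F)(F)F)c1)N1CCC(n2cncc2-c2ccc(OS(=O)(=O)c3ccccc3)cc2)CC1` gives 702 nM in this assay.
Compound 3 `O=C(c1ccc(Cl)c(C(F)(F)F)c1)N1CCC(n2cncc2-c2ccc(OS(=O)(=O)c3cccs3)cc2)CC1` gives 238 nM in this assay.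

Compound 3 stands lowest of the three measured compounds: the step from compound 1 to compound 3 is a 6.6-fold lower number from compound 1 to compound 3 (0.82 log units; beyond the scatter), and the step from compound 2 to compound 3 is a 2.9-fold lower number from compound 2 to compound 3 (0.47 log units; beyond the scatter). Compound 4 `O=C(c1ccc(Cl)c(C(F)(F)F)c1)N1CCC(n2cncc2-c2ccc(OS(=O)(=O)c3cccc4ccccc34)cc2)CC1` differs from compound 3 in one place: naphthalen-1-yl in place of thiophen-2-yl on a sulfonyl sulfur. All three measured steps concern the same position, the group on the sulfonyl sulfur, and so all bear on this change. Exchanging methyl for phenyl gave a 2.2-fold lower number from compound 1 to compound 2 (0.35 log units; beyond the scatter), exchanging methyl for thiophen-2-yl gave a 6.6-fold lower number from compound 1 to compound 3 (0.82 log units; beyond the scatter), and exchanging phenyl for thiophen-2-yl gave a 2.9-fold lower number from compound 2 to compound 3 (0.47 log units; beyond the scatter). Among the compounds with values here, each aromatic group in place of methyl lowered the number, yet the two aromatic groups themselves differ beyond the scatter, and no step with a bicyclic group has been measured. The step from compound 3 to compound 4 is therefore expected to be small, a 1.5-fold higher number from compound 3 to compound 4 (0.17 log units; within the scatter), with either direction possible. Compound 4 is estimated at 350 nM, in the range 90 nM to 1400 nM.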

Compound 4, half-maximal inhibitory concentration: 3520 nM
Beside the measured number, compound 4's estimate is 10-fold (1.00 log units) below it; the measured number lies above the stated range.
By their numbers in this assay, from the lowest: compound 3; then compound 2; then compound 1; then compound 4.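

In this assay the group on the sulfonyl sulfur does not simply reward any aromatic ring: naphthalen-1-yl in place of methyl gives a 2.2-fold higher number from compound 1 to compound 4 (0.35 log units; beyond the scatter) and so runs against phenyl and thiophen-2-yl, which both lowered the number from methyl. Its two aromatic rings of carbon only also compare poorly with the single rings, with a 5.0-fold higher number from compound 2 to compound 4 (0.70 log units; beyond the scatter) from phenyl and a 15-fold higher number from compound 3 to compound 4 (1.17 log units; beyond the scatter) from thiophen-2-yl, the latter the largest step yet seen at this position. Nothing given here accounts for this reversal.

The compounds shown leave open whether the rise follows the second ring itself or the way it is attached, which naphthalen-2-yl would address. They also leave open whether a single ring such as furan-2-yl or 3-thienyl would hold the lower numbers seen with thiophen-2-yl.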